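This account rests on a few compounds, and the source may have more. Where it says the series, first, only, none or still open, it means among the compounds named here.

Measured in a functional assay on MCF7 cells (Homo sapiens) for antiproliferative activity, read by MTT assay, with a stated time of 48 h; on this read-out lower numbers stand for stronger inhibition and higher numbers for weaker inhibition:
- compound 1 `Cc1ccc(/C=C/C(=O)Nc2nnc(-c3ccc(Cl)cc3)s2)cc1` gives 1.44 ug/mL
- compound 2 `O=C(/C=C/c1ccccc1)Nc1nnc(-c2ccc(Cl)cc2)s1` gives 1.42 ug/mL
- compound 3 `COc1ccc(/C=C/C(=O)Nc2nnc(-c3ccc(Cl)cc3)s2)cc1` gives 0.91 ug/mL

Compound 1 does not separate from the other two: a 1.0-fold lower number from compound 1 to compound 2 (0.01 log units; within the scatter) and a 1.6-fold lower number from compound 1 to compound 3 (0.20 log units; within the scatter) both lie within the scatter, as does a 1.6-fold lower number from compound 2 to compound 3 (0.19 log units; within the scatter) in the remaining comparison.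

Compound 4 `Cc1ccc(/C=C/C(=O)Nc2nnc(-c3ccc(Br)cc3)s2)cc1` has not yet been measured. Its difference from compound 1 is bromo in place of chloro on an aromatic carbon and reads as bromo in place of chloro on an aromatic carbon, or 4-chlorophenyl to 4-bromophenyl. For the measured compounds named here, no measured step makes this exchange, since all three keep the chloro group and vary another substituent. Going by the values given here, they therefore bear on it only indirectly, and the data hold no measured halogen step. In this assay the step is expected to stay within the scatter. The estimate starts from compound 1 at 1.44 ug/mL in this series. The expected change is a 1.0-fold lower number from compound 1 to compound 4 (0.01 log units; within the scatter) and remains an estimate within the scatter. For compound 4 the estimated value is 1.4 ug/mL with an expected range from 0.7 ug/mL to 2.8 ug/mL pending measurement.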

Compound 4, half-maximal inhibitory concentration: 1.32 ug/mL
For compound 4 the middle estimate is 1.1-fold (0.03 log units) above the measured one, and the stated range covers the measured number.
By their numbers in this assay, from the lowest: compounds 3, 4, 2 and 1 (each within the scatter of the next).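

In this assay the halogen exchange now has a measured step of its own, a 1.1-fold lower number from compound 1 to compound 4 (0.04 log units; within the scatter) and so bromo in place of chloro, on an aromatic carbon para to a large group, does not separate the two compounds. The change from 4-chlorophenyl to 4-bromophenyl therefore leaves the read-out within the scatter for this one pair, with the methyl group held fixed. No measured evidence is available to account for this result.

From the compounds shown here alone, whether the same exchange reads alike with hydrogen or methoxy in place of that methyl remains open. Also open, going by these compounds, is how fluoro, an amine or a carboxylic acid would read at the halogen position, since chloro and bromo alone span only a narrow choice of groups there.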